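Cyclohexylmethyl to 4-bromobenzyl on the shared core

The compounds below may be only part of what the source reports. "The series", "measured", "known", "first", "only" and "open" are said of these compounds alone.

In a functional assay on THP-1 cells (Homo sapiens) for inhibition, read by luminescence, with a stated time of 72 h, tested at 5 uM (a higher number here means more inhibition of growth at the concentration tested, a lower number less inhibition of growth), compound 1 `C=CS(=O)(=O)NC/C=C/c1cc(OC)cc(O)c1C(=O)OC(C)C`, bearing isopropyl on the oxygen next to the carbonyl group, gives 19.9%. Compound 2 `C=CS(=O)(=O)NC/C=C/c1cc(OC)cc(O)c1C(=O)OCC1CCCCC1`, bearing cyclohexylmethyl there, gives 26.5%, and the two values lie within the scatter of each other. Compound 3 `C=CS(=O)(=O)NC/C=C/c1cc(OC)cc(O)c1C(=O)OCc1ccc(Br)cc1` has 4-bromophenyl in place of cyclohexyl on a saturated chain carbon bound to an oxygen next to a carbonyl group. Among the compounds with values here, one measured step bears on this change: a number 6.6 percentage points higher from compound 1 to compound 2 (within the scatter). Within the data shown here, it alters the same substituent and stays within the scatter, but no aromatic group has yet been measured at this place, so the guidance is weak. No change beyond the scatter is therefore expected, and a number 1.5 percentage points higher from compound 2 to compound 3 (within the scatter) is the estimated step. For compound 3 the expected value is 28%, with an estimated range of 10% to 52%.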

Compound 3, percent growth inhibition at one concentration: 31.2%
Beside the measured number, compound 3's estimate is 3.2 percentage points below it; the range from low to high includes it.
By their numbers in this assay, from the lowest: compounds 1, 2 and 3 (each within the scatter of the next, the first and the last beyond it).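

An aromatic ring at this place is tolerated in this assay: 4-bromophenyl in place of cyclohexyl gives a number 4.7 percentage points higher from compound 2 to compound 3 (within the scatter) and so does not separate the two groups. Taken against isopropyl, 4-bromobenzyl gives a number 11.3 percentage points higher from compound 1 to compound 3 (beyond the scatter) as the first step at this place beyond the scatter, though only a modest one, while cyclohexylmethyl stays within the scatter of both isopropyl and 4-bromobenzyl. No available evidence accounts for these steps.

The compounds shown leave open whether the modest step from isopropyl belongs to the phenyl ring or to its bromine, a question that plain benzyl or 4-chlorobenzyl at this place would address. Also open, on these data alone, is how this place responds to groups of another kind, such as a chain ending in an amine or a carboxylic acid.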